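Halogen pattern on the aryl ring at the thiocarbonyl nitrogen

The source may report more compounds than this note shows. Statements on the series, on what has been measured and on what is new or still open speak of the compounds shown alone.

Compound 1, `CNC(=O)c1ccc(Oc2cccc(NC(=S)Nc3ccc(C)cc3)c2)nc1`, returns in a functional assay on PC-3 cells (Homo sapiens) for antiproliferative activity, read by MTT assay (a lower number here means a stronger inhibitor, a higher number a weaker inhibitor), only a limit, > 100000 nM. Compound 2, `CNC(=O)c1ccc(Oc2cccc(NC(=S)Nc3ccc(F)cc3)c2)nc1`, gives 32700 nM. Compound 3, `CNC(=O)c1ccc(Oc2cccc(NC(=S)Nc3ccc(Cl)cc3Cl)c2)nc1`, gives 19300 nM.

Compound 3 holds the lowest of the two numbers shown; compound 2 is nearest, and the gap a 1.7-fold lower number from compound 2 to compound 3 (0.23 log units; within the scatter) sits inside the scatter, so no order between the two is claimed. Compound 1 stands apart as a limit (the limit of > 100000 nM in this assay, at which 1 of the 3 values shown sits), with an at least 3.0-fold lower number from compound 1 to compound 2 (0.48 log units; beyond the scatter) and an at least 5.1-fold lower number from compound 1 to compound 3 (0.71 log units; beyond the scatter) both beyond the scatter.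

Compound 4, `CNC(=O)c1ccc(Oc2cccc(NC(=S)Nc3ccc(F)c(Cl)c3)c2)nc1`, is unmeasured. It differs from compound 3 by 3-chloro-4-fluorophenyl in place of 2,4-dichlorophenyl on an amide-type nitrogen. Both the shown numbers come from halogenated aryl rings in this position, and the step between them, a 1.7-fold lower number from compound 2 to compound 3 (0.23 log units; within the scatter), is within the scatter; the one change that moved the number beyond the scatter was leaving the 4-methylphenyl of compound 1. Compound 4 keeps a halogenated ring, with a fluorine shared with compound 2 and a chlorine shared with compound 3, so the expected step of a 1.1-fold higher number from compound 3 to compound 4 (0.06 log units; within the scatter) is none beyond the scatter. Compound 4 is therefore estimated at 22000 nM, with a range from 8000 nM to 55000 nM.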

Compound 4, half-maximal inhibitory concentration: 18400 nM
For compound 4 the middle estimate is 1.2-fold (0.08 log units) above the measured one, within the range that was stated.
By their numbers in this assay, from the lowest: compounds 4, 3 and 2 (each within the scatter of the next). At a limit, above all of these: compound 1.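

Exchanging 2,4-dichlorophenyl for 3-chloro-4-fluorophenyl on the amide-type nitrogen leaves no readable difference in this assay, with a 1.0-fold lower number from compound 3 to compound 4 (0.02 log units; within the scatter), so two different halogen patterns on this ring cannot be told apart. Adding chloro to the 4-fluorophenyl ring also gives no readable difference, with a 1.8-fold lower number from compound 2 to compound 4 (0.25 log units; within the scatter), so the three halogenated rings form a single group with no order among them. The only step from compound 4 that lies beyond the scatter is the one involving 4-methylphenyl, an at least 5.4-fold lower number from compound 1 to compound 4 (0.73 log units; beyond the scatter), and its size is only a bound, since compound 1 gives a limit rather than a number: the limit of > 100000 nM in this assay, at which 1 of the 4 values shown sits.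

Going by these compounds, it remains open whether the separation of compound 1 from the others reflects the presence of halogen or only the absence of the methyl group; phenyl without a substituent, methoxyphenyl or trifluoromethylphenyl on the same nitrogen would bear on that question. Also open, on these data alone, is whether any ring at this position gives a clearly lower number than the halogenated group, and what a carbonyl in place of the thiocarbonyl would do to the number.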